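Compound 4 after three limits in the cytotoxicity assay

This account rests on a few compounds, and the source may have more. Where it says the series, first, only, none or still open, it means among the compounds named here.

- compound 1 `CCOC(=O)c1c(-c2cccc(F)c2)[nH]c2cc(OC)c(F)cc2c1=O` gives > 22000 nM as a limit
- compound 2 `CCOC(=O)c1c(-c2cccc(Cl)c2)[nH]c2cc(OC)c(F)cc2c1=O` gives > 22000 nM as a limit
- compound 3 `CCOC(=O)c1c(-c2cccc(Br)c2)[nH]c2cc(OC)c(F)cc2c1=O` gives > 22000 nM as a limit

These results come from an ADME assay on HEK293 cells (Homo sapiens) for cytotoxicity, read by luminescence, with a stated time of 72 h (a higher number here means that more compound is needed for the effect, a lower number that less compound is needed), and none of them is an exact number. Compound 3 has only the limit > 22000 nM as its result. Across the series the picture is the limit of > 22000 nM in this assay, at which 3 of the 3 values shown sit, and no measured compound has a number.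

Compound 4 `CCOC(=O)c1c(-c2cccc(-c3nc(C)c(C)s3)c2)[nH]c2cc(OC)c(F)cc2c1=O` carries a 4,5-dimethyl-1,3-thiazol-2-yl in place of bromo on an aromatic carbon. Among the compounds with values here, three measured steps bear on this place, where fluoro, chloro and bromo replace one another. They are a step that the two limits leave unreadable from compound 1 to compound 2 and a step that the two limits leave unreadable from compound 1 to compound 3 and a step that the two limits leave unreadable from compound 2 to compound 3 and so none has a size to carry over. None of them brings in a ring, so they offer only weak guidance for compound 4.

Within the data shown here, no step of readable size can therefore be expected in this assay and a further limit is the likeliest outcome. The expectation rests on compound 3 with its limit > 22000 nM and on nothing firmer. The expected step is a number no higher from compound 3 to compound 4 (the limit leaves the size open) and it remains an estimate. The estimated value for compound 4 is 22000 nM with 8000 nM to 45000 nM as its expected range.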

Compound 4, half-maximal effective concentration: > 22000 nM
Compound 4: only a limit was reported (the forecaster's own chance of this, stated with the estimate: 75%); the middle value lies on the limit itself.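

In this assay compound 4 gives > 22000 nM, which is a limit and not a number. Within the data shown here, compound 1, compound 2 and compound 3 also have only limits, so no step to compound 4 can be read. The compounds shown leave open how much of each is needed for the effect, and so whether fluoro, chloro, bromo or 4,5-dimethyl-1,3-thiazol-2-yl makes any difference, with the whole series at one value: the limit of > 22000 nM in this assay, at which 4 of the 4 values shown sit.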